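Ring-Closing the Amino Acid Tail of a Stilbene

This account rests on a few compounds, and the source may have more. Where it says the series, first, only, none or still open, it means among the compounds named here.

Compound 1 `COc1ccc(/C=C\c2cc(OC)c(OC)c(OC)c2)cc1OCc1ccc(CN2CC[C@H](C(=O)O)C2)cc1` gives 6400 nM in a functional assay on HepG2 cells (Homo sapiens) for antiproliferative activity, read by CCK-8 assay, with a stated time of 48 h; a lower number here means a stronger inhibitor, a higher number a weaker inhibitor. Compound 2 `COc1ccc(/C=C\c2cc(OC)c(OC)c(OC)c2)cc1OCc1ccc(CN[C@H](C(=O)O)[C@H](C)O)cc1` reaches only the limit of this assay, giving > 10000 nM, so no number is known for it. Compound 3 `COc1ccc(/C=C\c2cc(OC)c(OC)c(OC)c2)cc1OCc1ccc(CN2CC(C(=O)O)C2)cc1` likewise stops at the limit, giving > 10000 nM in this assay. The steps of an at least 1.5-fold higher number from compound 1 to compound 2 (0.19 log units; that floor lies within the scatter) and an at least 1.5-fold higher number from compound 1 to compound 3 (0.19 log units; that floor lies within the scatter) both end at this limit (the limit of > 10000 nM in this assay, at which 2 of the 3 values shown sit), while the step that the two limits leave unreadable from compound 2 to compound 3. Compound 4 `COc1ccc(/C=C\c2cc(OC)c(OC)c(OC)c2)cc1OCc1ccc(CN2C[C@H](O)C[C@@H]2C(=O)O)cc1` carries 2-carboxy-4-hydroxypyrrolidin-1-yl in place of (1-carboxy-2-hydroxypropyl)amino on a saturated chain carbon bound to an aromatic carbon. Given the step of an at least 1.5-fold higher number from compound 1 to compound 3 (0.19 log units; that floor lies within the scatter), a ring-bound acid on its own did not lift compound 3 off the limit, and compound 4 is expected to stay weak, with an estimated step that the limit leaves unreadable from compound 2 to compound 4 within the scatter. Compound 4 is therefore expected to give 11000 nM, within 5000 nM to 30000 nM.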

Compound 4, half-maximal inhibitory concentration: > 10000 nM
Compound 4 gave a limit, no number; the forecaster's own chance of this, stated with the estimate: 60%; the middle value does not contradict the limit.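

In this assay, 2-carboxy-4-hydroxypyrrolidin-1-yl on a saturated chain carbon bound to an aromatic carbon yields no number, so a five-membered ring bearing both the acid and a hydroxyl does not by itself give a readable value. Within the data shown here, the one readable step is an at least 1.5-fold higher number from compound 1 to compound 4 (0.19 log units; that floor lies within the scatter). The steps from compound 2 and compound 3 to compound 4 cannot be read, because each joins two limits: the limit of > 10000 nM in this assay, at which 3 of the 4 values shown sit.

Still open, going by these compounds, is how far apart compound 2, compound 3 and compound 4 truly lie. Also open, on these data alone, is whether a piperidine ring carrying the acid, or a methyl ester in place of the carboxylic acid, would give a measurable number.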